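This account rests on a few compounds, and the source may have more. Where it says the series, first, only, none or still open, it means among the compounds named here.

Series notes, aryl substituent on the shared core.

Compound 1 `Cc1cccc(-c2cn3ccnc3c(-c3ccc4ncn(Cc5ccccc5)c4c3)n2)c1` carries a 3-methylphenyl group and in a functional assay on Hs-578T cells (Homo sapiens) for inhibition, read by sulforhodamine B assay, with a stated time of 48 h, tested at 10 uM (on this read-out higher numbers stand for more inhibition at the one concentration tested (going by the name of the read-out) and lower numbers for less inhibition), compound 1 gives 8.47%. Compound 2 `O=Cc1ccc(-c2cn3ccnc3c(-c3ccc4ncn(Cc5ccccc5)c4c3)n2)cc1` carries a 4-formylphenyl group in the same place, and in this assay compound 2 gives 45.5%. Among the measured compounds shown here, the single step measured so far, a number 37 percentage points higher from compound 1 to compound 2 (beyond the scatter), is large and lies beyond the scatter. For the measured compounds named here, on the two numbers available compound 2 stands highest, with compound 1 the only neighbour and well below it.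

Compound 3 `c1ccc(Cn2cnc3ccc(-c4nc(-c5cccc6ccccc56)cn5ccnc45)cc32)cc1` is the next member: naphthalen-1-yl in place of 4-formylphenyl on an aromatic carbon. Going by the values given here, the only step that bears on this change is a number 37 percentage points higher from compound 1 to compound 2 (beyond the scatter), which shows that the compound carrying the 4-formylphenyl group read far higher than the one carrying a plain hydrocarbon ring. The naphthalen-1-yl group of compound 3 likewise brings no hydrogen-bond acceptor, so the expectation is that the formyl-bearing compound's advantage is lost, and a downward step of a number 30.5 percentage points lower from compound 2 to compound 3 (beyond the scatter) is expected in this assay. Going by these compounds, whether the second fused ring of naphthalen-1-yl adds anything beyond what 3-methylphenyl gave is unknown from these two compounds.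

Compound 3 is therefore estimated at 15%, with a range from 0% to 38%.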

Compound 3, a percentage reported as inhibition, at one concentration (the size of the read-out at that concentration, not a potency) in the Hs-578T assay: 5.98%
For compound 3 the middle estimate is 9 percentage points above the measured one, and the stated range covers the measured number.
By their numbers in the Hs-578T assay, from the lowest: compounds 3 and 1 (each within the scatter of the next); then compound 2.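

In the Hs-578T assay compound 3 gives 5.98% and the change to naphthalen-1-yl gives a number 39.5 percentage points lower from compound 2 to compound 3 (beyond the scatter) and the change from 3-methylphenyl gives a number 2.5 percentage points lower from compound 1 to compound 3 (within the scatter) so the second carbon-only aromatic ring of naphthalen-1-yl gives no separation from 3-methylphenyl at this position, and only the 4-formylphenyl compound stands apart among the three. In a physicochemical assay for lipophilicity, using the shake flask method, in phosphate buffer, measured as octanol-water partition, with a stated time of 85 min, at pH 7.4 (on this read-out higher numbers stand for higher lipophilicity and lower numbers for lower lipophilicity), compound 2 gives 1.88 and compound 3 gives 2 and the change from 4-formylphenyl to naphthalen-1-yl gives a number 0.12 log units higher from compound 2 to compound 3 (within the scatter) so the large step in inhibition is not matched by a partition step beyond the scatter for this pair. Nothing available explains why the 4-formylphenyl group reads apart from the two other aryl groups.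

Compound 2 differs from compound 1 in both the group and its place on the phenyl ring, so 3-formylphenyl and 4-methylphenyl would be needed to tell whether the higher reading follows the formyl group or the 4-position. Also open, going by these compounds, is how other groups on the phenyl ring at this position would read, such as a carboxylic acid, an amine or a nitrile, and whether any of them would match or pass the 4-formylphenyl compound.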